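Aryl replacement on the shared core of compound 1

A few compounds are considered here, and "the series" means these few. Any claim that something is new, unique, unknown or untested is made for them only; others in the source may bear on it.

Compound 1 `O=C(O)Cc1sc(C(c2ccc(F)cc2)c2ccc(F)cc2)nc1-c1ccnc(N2CCCC2)c1` holds the higher of the two numbers: in an in vitro functional assay on HEK285-7 cells for antagonist activity at prostaglandin D2 receptor 2 (Homo sapiens), read by BRET and beta-arrestin recruitment (on this read-out higher numbers stand for larger maximal responses and lower numbers for smaller maximal responses), compound 1 gives 80%. Going by the values given here, compound 2 `CCC(c1ccccc1)c1nc(-c2ccc(Cl)cc2)c(CC(=O)O)s1` lies below it, and in this assay compound 2 gives 50%, a gap beyond the scatter; no single-point step connects these two. Compound 3 `O=C(O)Cc1sc(C(c2ccc(F)cc2)c2ccc(F)cc2)nc1-c1ccccc1` is unmeasured and differs from compound 1 by phenyl in place of 2-(pyrrolidin-1-yl)pyridin-4-yl on an aromatic carbon. Among the compounds with values here, no step of this kind has been measured. A decrease beyond the scatter is expected, a number 25 percentage points lower from compound 1 to compound 3 (beyond the scatter). Compound 3 is estimated in this assay at 55%, with a range from 35% to 75%.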

Compound 3, largest response reached (reported as efficacy), in percent of the reference or control that the assay uses: 80%
Estimate against measurement, compound 3: 25 percentage points below, outside the stated range (above it).
By their numbers in this assay, from the lowest: compound 2; then compounds 1 and 3 (each within the scatter of the next).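

In this assay, phenyl in place of 2-(pyrrolidin-1-yl)pyridin-4-yl on this aromatic carbon, next to the ring nitrogen, gives no change at the digits printed from compound 1 to compound 3 (within the scatter). On the shared core, neither the pyrrolidine ring nor the pyridine ring nitrogen is therefore needed to retain this maximal response, and the position accepts both aryl groups. Nothing available accounts for this level result. Still open, as far as these compounds go, is how a methyl group or a morpholin-4-yl group on this carbon would read out. Also open, from the compounds shown here alone, is whether a chlorine atom on the phenyl ring would alter the response on this core.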